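Oral exposure in monkey: swapping a sulfonamide for an acylsulfonamide

The compounds below may be only part of what the source reports. "The series", "measured", "known", "first", "only" and "open" are said of these compounds alone.

Measured compounds:
compound 1, `C[C@H](c1ccc(-c2cc(Cl)ccc2-c2nc(=O)o[nH]2)cc1)N(CC1CC1)c1nc2c(C(=O)O)cccc2o1`: 976 nM
compound 2, `CCCCN(c1nc2c(NS(C)(=O)=O)cccc2o1)[C@H](C)c1ccc(-c2ccccc2-c2nnn[nH]2)cc1`: 49.9 nM

Of the compounds shown here, two have been tested in an ADME assay on the whole organism (Macaca fascicularis) for pharmacokinetics, read by LC-MS, using cassette dosing, at a dose of 1 mg/kg by the oral route; on this read-out higher numbers stand for higher exposure at the dose given and lower numbers for lower exposure. Compound 1 gives 976 nM and compound 2 gives 49.9 nM, so compound 2 holds the lower of the two numbers, and the gap to compound 1 lies well beyond the usual scatter of this assay. The two compounds differ in several places at once, so their two values alone say nothing about any single change.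

Compound 3, `CCCCN(c1nc2c(C(=O)NS(C)(=O)=O)cccc2o1)[C@H](C)c1ccc(-c2ccccc2-c2nnn[nH]2)cc1`, is built from compound 2 by one change: (methylsulfonyl)carbamoyl in place of methanesulfonamido on an aromatic carbon. The carbonyl that is inserted between the aromatic ring and the sulfonamide nitrogen is the only new feature. Among the measured compounds shown here, no measured pair shows this exact change, so the expectation rests on compound 2 alone. A small rise in exposure is expected for compound 3, with a 1.8-fold higher number from compound 2 to compound 3 (0.26 log units; within the scatter), though a step inside the scatter would not be surprising. Compound 3 is therefore estimated at 90 nM in this assay, with a range from 25 nM to 350 nM.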

Compound 3, maximal plasma concentration: 40.4 nM
Beside the measured number, compound 3's estimate is 2.2-fold (0.35 log units) above it; the range from low to high includes it.
By their numbers in this assay, from the lowest: compounds 3 and 2 (each within the scatter of the next); then compound 1.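

In this assay, replacing methanesulfonamido with (methylsulfonyl)carbamoyl on this aromatic carbon gives a 1.2-fold lower number from compound 2 to compound 3 (0.09 log units; within the scatter), so the two groups cannot be told apart on this read-out. Among the compounds shown here, this is the first comparison that isolates a single place, and it shows that the inserted carbonyl, the only new feature, does not shift maximal plasma concentration beyond the usual scatter in this pair of compounds; a larger effect of this swap would have been visible here, but none appears. No accompanying measurement bears on why the two groups read alike, so this result describes the outcome without explaining it.

On these data alone, it remains open whether a quite different group at this position, such as a primary amide or an amine on the core of compound 3, would produce a step beyond the scatter. Compound 1 differs from the other two compounds in several places at once, so its value cannot yet be tied to any one of its features, including the carboxylic acid it carries on this ring.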